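This account rests on a few compounds, and the source may have more. Where it says the series, first, only, none or still open, it means among the compounds named here.

In a functional assay on NCI-H1650 cells (Homo sapiens) for inhibition, read by MTT assay, with a stated time of 48 h (a higher number here means a weaker inhibitor of growth, a lower number a stronger inhibitor of growth), compound 1 (`O=S(=O)(NCCCN1CCCCc2ccccc21)c1ccc(Cl)cc1`) gives "not active" (no number reported) and compound 2 (`O=S(=O)(NCCCN(c1ccccc1)c1cccc(Cl)c1)c1ccc(Cl)cc1`) gives "not active" (no number reported) with no number reported. Among the compounds with values here, compound 3 (`O=S(=O)(NC1CCC2(OC1)c1ccccc1CCc1ccccc12)c1ccc(C(F)(F)F)cc1`) gives 15000 nM as the only number so far, so its standing can be judged against no other measured value. Compound 4 (`O=S(=O)(NC1CCC2(OC1)c1ccccc1CCc1ccccc12)c1ccccc1`) differs from compound 3 by one change (hydrogen in place of trifluoromethyl on an aromatic carbon): hydrogen in place of trifluoromethyl on an aromatic carbon, para to a large group. No measured step sizes this change in this assay, so the expectation is a step within the scatter, leaning toward weaker growth inhibition, with a real chance of no number being reported. The expected move is a 1.5-fold higher number from compound 3 to compound 4 (0.17 log units; within the scatter) (an estimate). Compound 4 is estimated at 22000 nM (expected range 9000 nM to 50000 nM).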

Compound 4, concentration for 50% growth inhibition: 22000 nM
The estimate for compound 4 equals the measured number at the digits printed; measured number inside the range.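

Replacing 4-(trifluoromethyl)phenyl with phenyl gives a 1.5-fold higher number from compound 3 to compound 4 (0.17 log units; within the scatter) in this assay and a number is still reported. On this shared core, trifluoromethyl at this position is therefore not required for a measurable value, and hydrogen serves about equally. Nothing available explains why this step is so small.

As far as these compounds go, whether an amine or a carboxylic acid at this position would move the number beyond the scatter remains open. From the compounds shown here alone, compound 1 and compound 2 differ from this pair in more than one place, so what separates them from it also remains open.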